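A Five-Membered Ring Enters the Chain of Compound 1

This account rests on a few compounds, and the source may have more. Where it says the series, first, only, none or still open, it means among the compounds named here.

In a physicochemical assay for lipophilicity, measured as octanol-water partition, at pH 7.4 (on this read-out lower numbers stand for lower lipophilicity and higher numbers for higher lipophilicity), compound 1 `Cc1ccc2[nH]c(C(=O)N[C@H]3CN(S(=O)(=O)c4ccccc4)C[C@@H]3C(=O)NCCN(C)C)cc2c1` gives 2.1, within the scatter of compound 3 `Cc1ccc2[nH]c(C(=O)N[C@H]3CN(S(=O)(=O)c4ccccc4)C[C@H]3C(=O)NCCN(C)C)cc2c1` at 2.3 and well clear of compound 2 `Cc1ccc2[nH]c(C(=O)N[C@H]3CN(S(=O)(=O)c4ccnnc4)C[C@@H]3C(=O)NCCN(C)C)cc2c1` at 0.7. Compound 4 `Cc1ccc2[nH]c(C(=O)N[C@H]3CN(S(=O)(=O)c4ccccc4)C[C@@H]3C(=O)NC[C@@H]3CCCN3C)cc2c1` departs from compound 1 in one place, on a saturated chain carbon bound to an amide-type nitrogen: 1-methylpyrrolidin-2-yl in place of (dimethylamino)methyl on a saturated chain carbon bound to an amide-type nitrogen. Neither measured step touches this place. One is a number 1.40 log units lower from compound 1 to compound 2 (beyond the scatter), with pyridazin-4-yl in place of phenyl on a sulfonyl sulfur. The other is a number 0.20 log units higher from compound 1 to compound 3 (within the scatter), given (the fact that compounds 1 and 3 differ only in the configuration as drawn). The expectation therefore starts from compound 1 at 2.1 and the counted change alone. A modest upward move is expected in this assay, namely a number 0.40 log units higher from compound 1 to compound 4 (beyond the scatter). Compound 4 is estimated at 2.5, with an expected range of 2.1 to 3.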

Compound 4, distribution coefficient: 2.3
Estimate against measurement, compound 4: 0.20 log units above; measured number inside the range.
By their numbers in this assay, from the lowest: compound 2; then compounds 1, 3 and 4 (each within the scatter of the next).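

In this assay, 1-methylpyrrolidin-2-yl in place of (dimethylamino)methyl gives a number 0.20 log units higher from compound 1 to compound 4 (within the scatter), so on a saturated chain carbon bound to an amide-type nitrogen, a five-membered non-aromatic ring can enter the chain with no step beyond the scatter. Going by these compounds alone, only this one pair speaks for this place, and nothing at hand accounts for the step.

From the compounds shown here alone, whether a piperidine ring, a primary amine or a longer chain at this place would stay as close to compound 1 remains open. So does the value of the opposite configuration at the stereocentre of the 1-methylpyrrolidin-2-yl group.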